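The source may hold more compounds than are shown below. What is called first, only, known or untested is meant among the compounds shown, and "the series" means these compounds.

In an ADME assay on microsomes from liver (Homo sapiens) for metabolic stability (on this read-out lower numbers stand for slow clearance and higher numbers for fast clearance), compound 3 `COc1cc([C@](O)(CCN(C)C)[C@@H](c2cc3cc(Br)ccc3nc2OC)c2cccc(OC)c2F)cc(OC(C)C)n1` gives 3.4 uL/min. Compound 1 `CCOc1cc([C@](O)(CCN(C)C)[C@@H](c2cc3cc(Br)ccc3nc2OC)c2cccc(OC)c2F)cc(OC)n1` gives 4.1 uL/min and compound 2 `CCOc1cc([C@](O)(CCN(C)C)[C@@H](c2cc3cc(Br)ccc3nc2OC)c2ccnc(OC)c2OC)cc(OC)n1` gives 3.8 uL/min, so the three numbers all sit within the usual scatter of one another, and compound 3 stands apart from neither of them. Compound 4 `COc1cc([C@](O)(CCN(C)C)[C@@H](c2cc3cc(Br)ccc3nc2OC)c2ccnc(OC)c2OC)cc(OC(C)C)n1` has not yet been measured. It differs from compound 3 in one place: 2,3-dimethoxypyridin-4-yl in place of 2-fluoro-3-methoxyphenyl on a saturated chain carbon bound to an aromatic carbon and a saturated chain carbon. The same exchange has been seen once already, between two compounds that share every other feature, and there it gave a 1.1-fold lower number from compound 1 to compound 2 (0.03 log units; within the scatter). The other measured step, a 1.2-fold lower number from compound 1 to compound 3 (0.08 log units; within the scatter), was likewise small. On that basis a step of a 1.1-fold lower number from compound 3 to compound 4 (0.03 log units; within the scatter) is expected, nothing beyond the scatter. Compound 4 is therefore estimated at 3.2 uL/min, with a range from 1.8 uL/min to 5.5 uL/min.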

Compound 4, intrinsic clearance in a liver preparation (reported as CLH), per the amount of preparation that the assay uses: 6.4 uL/min
Estimate against measurement, compound 4: 2.0-fold (0.30 log units) below; the whole stated range lies below it.
By their numbers in this assay, from the lowest: compounds 3, 2, 1 and 4 (each within the scatter of the next).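

In this assay, 2,3-dimethoxypyridin-4-yl in place of 2-fluoro-3-methoxyphenyl now gives a 1.9-fold higher number from compound 3 to compound 4 (0.27 log units; within the scatter), so this change has been read on a second core, and the two readings do not separate: the same change on two cores in this assay, a 1.1-fold lower number (0.03 log units; within the scatter) from compound 1 to compound 2 and a 1.9-fold higher number (0.27 log units; within the scatter) from compound 3 to compound 4, 2.0-fold (0.31 log units) apart, within the scatter of two such steps

Methyl in place of hydrogen on the saturated chain carbon bound to an oxygen on an aromatic ring gives a 1.7-fold higher number from compound 2 to compound 4 (0.23 log units; within the scatter), and its two readings do not separate either: the same change on two cores in this assay, a 1.2-fold lower number (0.08 log units; within the scatter) from compound 1 to compound 3 and a 1.7-fold higher number (0.23 log units; within the scatter) from compound 2 to compound 4, 2.0-fold (0.31 log units) apart, within the scatter of two such steps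

Neither change, on either core, moves the clearance number beyond the scatter.

Still open, as far as these compounds go, is whether an amine in place of the 2,3-dimethoxypyridin-4-yl, or a longer chain in place of the added methyl, would give a step beyond the scatter.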